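Swapping a Chlorine for a Hydroxyl on the Aryl Group

This account rests on a few compounds, and the source may have more. Where it says the series, first, only, none or still open, it means among the compounds named here.

Three compounds share one core and differ only in the aromatic group attached to the ring nitrogen. Compound 1 `CC1(C)[C@H]2CC[C@]1(C)N(Cc1cn(-c3cccc(Cl)c3)nn1)C(=O)C2` carries 3-chlorophenyl, compound 2 `CC1(C)[C@H]2CC[C@]1(C)N(Cc1cn(-c3ccc(Cl)cc3)nn1)C(=O)C2` carries 4-chlorophenyl, and compound 3 `Cc1ccccc1-n1cc(CN2C(=O)C[C@@H]3CC[C@@]2(C)C3(C)C)nn1` carries 2-methylphenyl. In a functional assay on SGC-7901 cells (Homo sapiens) for inhibition, read by MTT assay, with a stated time of 24 h (on this read-out lower numbers stand for stronger inhibition and higher numbers for weaker inhibition), compound 1 gives 510 nM, compound 2 gives 410 nM and compound 3 gives 350 nM. Compound 2 sits between the other two, with a 1.2-fold lower number from compound 1 to compound 2 (0.09 log units; within the scatter) and a 1.2-fold lower number from compound 2 to compound 3 (0.07 log units; within the scatter), while the remaining pair shows a 1.5-fold lower number from compound 1 to compound 3 (0.16 log units; within the scatter); none of the three steps reaches beyond the scatter. Compound 4 `CC1(C)[C@H]2CC[C@]1(C)N(Cc1cn(-c3ccccc3O)nn1)C(=O)C2` has not yet been measured. It differs from compound 2 in one place: 2-hydroxyphenyl in place of 4-chlorophenyl on an aromatic nitrogen. The measured steps bear on this only loosely, since each of them exchanged one aryl substituent for another without a hydrogen-bond donor or acceptor entering, and all of them stayed within the scatter. On that basis the expected step is a 1.0-fold higher number from compound 2 to compound 4 (0.01 log units; within the scatter), no larger than the scatter. Compound 4 is therefore estimated at 420 nM, with a range from 150 nM to 1200 nM.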

Compound 4, half-maximal inhibitory concentration: 410 nM
For compound 4 the middle estimate is 1.0-fold (0.01 log units) above the measured one, within the range that was stated.
By their numbers in this assay, from the lowest: compounds 3, 2, 4 and 1 (each within the scatter of the next).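

Compound 4 brings a hydroxyl onto the aryl group, and so a hydrogen-bond donor and acceptor that the earlier aryl groups lack, yet in this assay the exchange for 4-chlorophenyl gives (no change at the digits printed from compound 2 to compound 4 (within the scatter)). Hydroxy in place of methyl on the aromatic carbon gives (a 1.2-fold higher number from compound 3 to compound 4 (0.07 log units; within the scatter)), and the exchange for 3-chlorophenyl gives (a 1.2-fold lower number from compound 1 to compound 4 (0.09 log units; within the scatter)), so all four aryl groups shown fall within the scatter of one another in this cell assay. No measurement at hand explains this flat result.

From the compounds shown here alone, it remains open whether a 2-aminophenyl or 2-carboxyphenyl group would also stay within the scatter. Going by these compounds, it is equally open whether a longer chain in place of the aryl ring would shift the number beyond it.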